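The source may report more compounds than this note shows. Statements on the series, on what has been measured and on what is new or still open speak of the compounds shown alone.

Measured compounds:
compound 1, `CC(C)=CCC/C(C)=C/CC/C(C)=C/CSc1ccccc1C(=O)N[C@@H](C)C(=O)OCCOCCOc1no[n+]([O-])c1S(=O)(=O)c1ccccc1` — 11300 nM
compound 2, `CC(C)=CCC/C(C)=C/CC/C(C)=C/CSc1ccccc1C(=O)N1CCC[C@H]1C(=O)OC(C)CCOc1no[n+]([O-])c1S(=O)(=O)c1ccccc1` — 13900 nM
compound 3, `CC(C)=CCC/C(C)=C/CC/C(C)=C/CSc1ccccc1C(=O)N1CCC[C@H]1C(=O)OCC#CCOc1no[n+]([O-])c1S(=O)(=O)c1ccccc1` — 7350 nM

Of the compounds shown here, three have been tested in a functional assay on SGC-7901 cells (Homo sapiens) for cytotoxicity, read by MTT assay, with a stated time of 48 h; on this read-out lower numbers stand for stronger inhibition and higher numbers for weaker inhibition. Compound 1 gives 11300 nM, the second highest of the three numbers. Its nearest neighbour is compound 2, which gives 13900 nM, a gap that lies within the usual scatter of the measurement. Compound 3 gives 7350 nM, the number furthest from compound 1, and that gap too lies within the scatter. Among the measured compounds shown here, the three values therefore cannot be told apart on this read-out, and none of the pairs differs at a single place, so no single-point step has been recorded among them.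

Compound 4, `CC(C)=CCC/C(C)=C/CC/C(C)=C/CSc1ccccc1C(=O)NCC(=O)OCCOCCOc1no[n+]([O-])c1S(=O)(=O)c1ccccc1`, has not yet been measured. It differs from compound 1 by hydrogen in place of methyl on a saturated chain carbon bound to an amide-type nitrogen and a carbonyl carbon. For the measured compounds named here, with no measured step to lean on, and the rest of the molecule unchanged, the step from compound 1 to compound 4 in this assay is expected to be none beyond the scatter, in either direction, as a 1.0-fold lower number from compound 1 to compound 4 (0.01 log units; within the scatter). Compound 4 is accordingly estimated at 11000 nM, with a range from 5000 nM to 25000 nM.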

Compound 4, half-maximal inhibitory concentration: 19500 nM
Compound 4: middle estimate off by 1.8-fold (0.25 log units), on the low side; low and high end bracket the measured number.
By their numbers in this assay, from the lowest: compounds 3, 1, 2 and 4 (each within the scatter of the next, the first and the last beyond it).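

In this assay, hydrogen in place of methyl on a saturated chain carbon bound to an amide-type nitrogen and a carbonyl carbon gives a 1.7-fold higher number from compound 1 to compound 4 (0.24 log units; within the scatter). Among the compounds shown here, this is the first step that changes a single place, and it shows that removing this methyl, with the rest of the molecule unchanged, leaves a difference that cannot be told from the usual scatter of the measurement, so this one step gives no sign that the methyl matters for the read-out, though a single pair cannot settle the point. Nothing available offers an explanation for the size or direction of this step.

The compounds shown leave open whether a larger group on the same carbon, such as an ethyl, an isopropyl or a benzyl, or a group carrying an amine or a carboxylic acid, would give a step beyond the scatter. For the compounds shown here, they also leave open whether the methyl in the opposite stereochemical arrangement would read the same as compound 1, and whether the same replacement would give a similar step in a compound with another chain in place of the one shared by compound 1 and compound 4.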